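Cytotoxicity of two quinazolinone analogues and a nitrile-bearing newcomer

The compounds below may be only part of what the source reports. "The series", "measured", "known", "first", "only" and "open" are said of these compounds alone.

The numbers here come from an ADME assay on L6 cells (Rattus norvegicus) for cytotoxicity, read by fluorescence and resazurin assay, with a stated time of 72 h; a lower number here means that less compound is needed, a higher number that more compound is needed for the effect. Compound 1, with the structure `O=c1nc(-c2ccccc2)c2cc(-c3ccccc3)ccc2[nH]1`, carries a phenyl group on the shared core. Compound 1 reaches only a limit of the assay, giving > 50000 nM. Compound 2, with the structure `Cn1ccc(-c2cccc3[nH]c(=O)nc(-c4ccccc4)c23)n1`, carries a 1-methyl-1H-pyrazol-3-yl group at the corresponding position instead. Compound 2 likewise reaches only a limit of the assay, giving > 50000 nM. Both results therefore sit together at the limit of > 50000 nM in this assay, at which 2 of the 2 values shown sit, so no number for either compound, and no difference between them, can be read from this assay.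

Compound 3, with the structure `N#Cc1ccc(-c2cccc3[nH]c(=O)nc(-c4ccccc4)c23)cc1`, has not yet been measured. It differs from compound 2 in one place: 4-cyanophenyl in place of 1-methyl-1H-pyrazol-3-yl on an aromatic carbon. With both measured compounds at the limit, no step size can be derived from the data, and the expected step from compound 2 to compound 3 is none beyond the scatter, about a step that the limit leaves unreadable from compound 2 to compound 3. Compound 3 is accordingly expected to give roughly 60000 nM, within 25000 nM to 150000 nM, most likely again reported only as a limit.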

Compound 3, half-maximal effective concentration: > 50000 nM
Compound 3: a limit, no number; the forecaster's own chance of this, stated with the estimate: 75%; the middle value is on the limit's open side.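

Putting 4-cyanophenyl in place of 1-methyl-1H-pyrazol-3-yl gives no readable step between compound 2 and compound 3, as both compounds stop at a limit in this assay: the limit of > 50000 nM in this assay, at which 3 of the 3 values shown sit.

The compounds shown leave open how much of each would be needed for the effect, and whether these groups on the shared core change that amount at all.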